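This account rests on a few compounds, and the source may have more. Where it says the series, first, only, none or still open, it means among the compounds named here.

Working notes on the series. In a functional assay on CCRF-CEM cells for antagonist activity at C-X-C chemokine receptor type 4 (Homo sapiens), read by calcium flux, with stated times of 25 min and 90 s (on this read-out lower numbers stand for stronger inhibition and higher numbers for weaker inhibition), compound 1 `CN(C[C@H]1Cc2c(cccc2N2CCN3CCC[C@@H]3C2)CN1)[C@H]1CCCc2cccnc21` gives 3.59 nM. Compound 2 `CN(C[C@H]1Cc2c(cccc2N2CCN(c3cccc(C(F)(F)F)c3)CC2)CN1)[C@H]1CCCc2cccnc21` returns only a limit in this assay, > 16700 nM, which is where it stands on the numbers shown (the limit of > 16700 nM in this assay, at which 1 of the 2 values shown sits). Compound 3 `CN1CCN(c2cccc3c2C[C@H](CN(C)[C@H]2CCCc4cccnc42)NC3)CC1` is not yet measured in this assay and differs from compound 2 by methyl in place of 3-(trifluoromethyl)phenyl on an amine nitrogen in a ring. Compound 3 carries a smaller group on that ring nitrogen, closer in size to the ring-bearing amine of compound 1, so an expected step of an at least 110-fold lower number from compound 2 to compound 3 (2.04 log units; beyond the scatter) toward stronger inhibition is estimated, well beyond the scatter. For compound 3 the estimate in this assay is 150 nM, with a range from 10 nM to 3000 nM.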

Compound 3, half-maximal inhibitory concentration: 29.6 nM
Estimate against measurement, compound 3: 5.1-fold (0.70 log units) above; the range from low to high includes it.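

In this assay, methyl in place of 3-(trifluoromethyl)phenyl on the ring amine nitrogen gives an at least 560-fold lower number from compound 2 to compound 3 (2.75 log units; beyond the scatter), so this nitrogen accepts methyl far better than the substituted phenyl. The reading for compound 2 is a limit, not a number: the limit of > 16700 nM in this assay, at which 1 of the 3 values shown sits. Changing the whole group on the aromatic carbon gives an 8.2-fold higher number from compound 1 to compound 3 (0.92 log units; beyond the scatter), so the methyl-bearing group does not match the group of compound 1.

Nothing shown lies between methyl and 3-(trifluoromethyl)phenyl on that nitrogen. A plain phenyl, an ethyl or a hydrogen there would show whether the loss follows the aromatic ring or the trifluoromethyl.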